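The source may hold more compounds than are shown below. What is called first, only, known or untested is meant among the compounds shown, and "the series" means these compounds.

Compound 2 `COC(=O)C1=C(CN2CCNC(=O)C2)NC(c2nccs2)=NC1(C)c1ccc(F)cc1` and compound 1 `COC(=O)C1=C(C)NC(c2nccs2)=NC1(C)c1ccc(F)c(F)c1` share one core and were both examined in a physicochemical assay for solubility, read by HPLC, in phosphate buffer, at pH 6.5; on this read-out higher numbers stand for higher solubility and lower numbers for lower solubility. In this assay compound 2 gives 34 ug/mL, while compound 1 gives 50 ug/mL; these two numbers lie within the usual scatter of each other, so neither stands apart. Compound 3 `COC(=O)C1=C(COC2CCOC2)NC(c2nccs2)=NC1(C)c1ccc(F)cc1` differs from compound 2 in one place: (oxolan-3-yl)oxy in place of 3-oxopiperazin-1-yl on a saturated chain carbon bound to a double-bonded ring carbon. For the measured compounds named here, no measured pair shows such a change, so only a small step, if any, is expected, leaning downward. Compound 3 is expected to give 25 ug/mL, roughly between 10 ug/mL and 60 ug/mL. That estimate means an expected step of a 1.4-fold lower number from compound 2 to compound 3 (0.13 log units; within the scatter).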

Compound 3, solubility: 30 ug/mL
For compound 3 the middle estimate is 1.2-fold (0.08 log units) below the measured one; the measured number falls inside the stated range.
By their numbers in this assay, from the lowest: compounds 3, 2 and 1 (each within the scatter of the next).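

In this assay, putting (oxolan-3-yl)oxy in place of 3-oxopiperazin-1-yl on a saturated chain carbon bound to a double-bonded ring carbon gives a 1.1-fold lower number from compound 2 to compound 3 (0.05 log units; within the scatter). For the compounds shown here, this is the first one-place comparison at this carbon, and it shows that a group with 0 hydrogen-bond donors and no ring nitrogen can replace one with 1 hydrogen-bond donor while the numbers stay within the scatter. Nothing available explains why these two groups read alike. Still open, as far as these compounds go, is whether a carboxylic acid or a basic amine such as piperidine on this carbon would give a number beyond the scatter.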